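The source may report more compounds than this note shows. Statements on the series, on what has been measured and on what is new or still open speak of the compounds shown alone.

Of the compounds shown here, three from this series have been measured in an assay on membranes from brain for displacement of a labelled ligand from Neuronal acetylcholine receptor; alpha4/beta2 (Rattus norvegicus); on this read-out lower numbers stand for stronger inhibition and higher numbers for weaker inhibition. Compound 1, `CN1CCC[C@H]1COc1cccnc1[N+](=O)[O-]`, gives 9000 nM in this assay. Compound 2, `CN1CCC[C@H]1COc1cnccc1Br`, gives 28 nM, and compound 3, `CN1CCC[C@H]1COc1cncc(C(F)(F)F)c1`, gives 1.83 nM, the lowest number of the three: its nearest neighbour is compound 2, whose number is higher by a margin beyond the scatter, while compound 1 lies far above both. No two of these compounds differ in one place only, so what the values of compound 1 and compound 2 show against compound 3 cannot be tied to a single structural change.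

Compound 4, `Cc1cncc(OC[C@@H]2CCCN2C)c1`, has not yet been measured. It differs from compound 3 by methyl in place of trifluoromethyl on an aromatic carbon. The core and the basic side chain are kept unchanged, and the group that enters sits at the place the trifluoromethyl leaves. Among the compounds with values here, with no single-change step measured in this set, the expected effect rests on the observation that compound 3 gives 1.83 nM in this assay with a small group at that position. The step from compound 3 to compound 4 is expected to be small, at most a mild weakening, a 1.9-fold higher number from compound 3 to compound 4 (0.28 log units; within the scatter). Compound 4 is therefore estimated to give 3.5 nM in this assay, with a likely range from 1 nM to 12 nM.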

Compound 4, inhibition constant: 0.48 nM
For compound 4 the middle estimate is 7.3-fold (0.86 log units) above the measured one; measured number outside the range, below it.
By their numbers in this assay, from the lowest: compound 4; then compound 3; then compound 2; then compound 1.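

Within the data shown here, the exchange of trifluoromethyl for methyl on an aromatic carbon, two atoms from the ring nitrogen, gives the first step that can be tied to a single structural change: in this assay there is a 3.8-fold lower number from compound 3 to compound 4 (0.58 log units; beyond the scatter). The step is modest but beyond the scatter, so this place in the molecule responds measurably to the group it carries, and in this pair the smaller methyl gives the lower number, with the core and side chain unchanged. The three fluorine atoms of the trifluoromethyl group are therefore not required for a low number at this place, though nothing available here accounts for why the number falls.

From the compounds shown here alone, only these two groups can be compared at this place, so it remains open how a bare hydrogen, a chlorine atom, a methoxy group, an amine or a longer chain such as ethyl would stand against methyl in this assay. Going by these compounds, it also remains open whether the same exchange would give a step of similar size on a core bearing a different side chain.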